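The source may report more compounds than this note shows. Statements on the series, on what has been measured and on what is new or still open speak of the compounds shown alone.

Measured so far:
- compound 1 `C[C@]1(CN2CCc3nc(-c4ccccc4)ccc3C2)Cn2cc([N+](=O)[O-])nc2O1` gives > 32 ug/mL
- compound 2 `C[C@]1(CN2CCc3nc(-c4ccc(OC(F)(F)F)cc4)ccc3C2)Cn2cc([N+](=O)[O-])nc2O1` gives "not determined" (no result reported)
- compound 3 `C[C@]1(CN2CCc3nc(-c4ccc(Cl)cc4)ccc3C2)Cn2cc([N+](=O)[O-])nc2O1` gives "not determined" (no result reported)

These three compounds share one core and differ only in the group attached to it. They were tested in an ADME assay on Vero cells (Chlorocebus sabaeus) for cytotoxicity, read by MTT assay, with a stated time of 72 h; on this read-out lower numbers stand for higher toxicity in this test and higher numbers for lower toxicity in this test. For compound 1 the result is not a number but a limit of the test, (the limit of > 32 ug/mL in this assay, at which 1 of the 3 values shown sits), meaning that no toxicity was seen up to the highest concentration tried. Within the data shown here, for compound 2 and compound 3 no result was reported, so compound 1 is the only point of reference, and no step between two measured compounds can be compared.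

The new compound is compound 4 `C[C@]1(CN2CCc3nc(-c4cc(F)cc(F)c4)ccc3C2)Cn2cc([N+](=O)[O-])nc2O1`. It differs from compound 1 in one place: 3,5-difluorophenyl in place of phenyl on an aromatic carbon.

Among the measured compounds shown here, with no measured step to go by, the expectation rests on compound 1 alone, whose result in this assay is the limit > 32 ug/mL. The step from compound 1 to compound 4 is expected to stay within the usual scatter of this test, a step that the limit leaves unreadable from compound 1 to compound 4, with no clear direction. For compound 4 the estimated value is therefore 40 ug/mL, within a range from 16 ug/mL to 100 ug/mL, and the test may again report only a limit.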

Compound 4, half-maximal cytotoxic concentration: > 32 ug/mL
Compound 4: a limit, no number (the forecaster's own chance of this, stated with the estimate: 70%); the middle value is on the limit's open side.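

No step can be read between compound 1 and compound 4 in this assay, because each result is a limit and not a number: the limit of > 32 ug/mL in this assay, at which 2 of the 4 values shown sit.

The compounds shown leave open whether 3,5-difluorophenyl in place of phenyl shifts the result in this assay at all, and, if it does, in which direction and by how much.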